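Thiophene in Place of Chlorophenyl on a Sulfonamide

The compounds below may be only part of what the source reports. "The series", "measured", "known", "first", "only" and "open" are said of these compounds alone.

Compound 1 `Cc1ccccc1S(=O)(=O)Nc1ccc2oc(-c3ccccc3)nc2c1` gives in an assay on isolated protein for inhibition of malate dehydrogenase, mitochondrial (Sus scrofa), with stated times of 45 min and 30 min (on this read-out higher numbers stand for weaker inhibition and lower numbers for stronger inhibition), only a limit, > 63000 nM.
Compound 2 `C=Cc1ccc(S(=O)(=O)Nc2ccc3oc(-c4ccccc4)nc3c2)cc1` gives in this assay only a limit, > 63000 nM.
Compound 3 `O=S(=O)(Nc1ccc2oc(-c3ccccc3)nc2c1)c1cccc(Cl)c1` gives in this assay only a limit, > 63000 nM.

All three measured compounds share one core and differ only in the aryl group on the sulfonyl sulfur. None of them gives a number in this assay; each sits at the limit of > 63000 nM in this assay, at which 3 of the 3 values shown sit. The steps between them are therefore unreadable: a step that the two limits leave unreadable from compound 1 to compound 2, a step that the two limits leave unreadable from compound 1 to compound 3 and a step that the two limits leave unreadable from compound 2 to compound 3. Compound 3 stands where the other two stand, at the limit, with no value to set it apart.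

Compound 4 `O=S(=O)(Nc1ccc2oc(-c3ccccc3)nc2c1)c1cccs1` is not yet measured. It differs from compound 3 in one place: thiophen-2-yl in place of 3-chlorophenyl on a sulfonyl sulfur. For the measured compounds named here, nothing among the measured steps shows a direction for this change, since every step so far is hidden by the limit, and the 2-methylphenyl, 4-vinylphenyl and 3-chlorophenyl groups all left the read-out at the limit.

The expectation for compound 4 in this assay is therefore another limit or a weak value, an estimated 100000 nM with a range from 30000 nM to 400000 nM, which means an expected step that the limit leaves unreadable from compound 3 to compound 4.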

Compound 4, half-maximal inhibitory concentration: > 63000 nM
Compound 4 ended at the assay's limit; the forecaster's own chance of this, stated with the estimate: 85%; the middle value does not contradict the limit.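

In this assay compound 4 gives > 63000 nM as a limit. Its steps from compound 1, compound 2 and compound 3 therefore cannot be read, and all four compounds stand together: the limit of > 63000 nM in this assay, at which 4 of the 4 values shown sit. The compounds shown leave open whether, in this assay, any group on the sulfonyl sulfur of the shared core gives a number rather than a limit.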